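Compound 1 at its limit, compound 3 still to come

The source may report more compounds than this note shows. Statements on the series, on what has been measured and on what is new or still open speak of the compounds shown alone.

Measured so far in an ADME assay on MRC5 cells (Homo sapiens) for cytotoxicity, read by MTT assay, with a stated time of 48 h; a higher number here means a weaker inhibitor, a lower number a stronger inhibitor:
compound 1 `O=C1Nc2ccc(Cl)cc2C1(c1c[nH]c2ccc(Br)cc12)c1c[nH]c2ccc(Br)cc12` gives > 100000 nM as a limit
compound 2 `O=C1Nc2ccccc2C1(c1c[nH]c2ccc(Cl)cc12)c1c[nH]c2ccc(Cl)cc12` gives > 100000 nM as a limit

Compound 1 stands at a limit of this assay with > 100000 nM and has no exact number. Compound 2 also ends at a limit, with > 100000 nM as its entry. Among the measured compounds shown here, the whole picture so far is this one ceiling (the limit of > 100000 nM in this assay, at which 2 of the 2 values shown sit), and no step between measured compounds can be read from it.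

Compound 3 `O=C1Nc2ccccc2C1(c1c[nH]c2ccc(Br)cc12)c1c[nH]c2ccc(Br)cc12` has yet to be measured. It differs from compound 1 in one place, with hydrogen in place of chloro on an aromatic carbon and the rest of the structure unchanged. For the measured compounds named here, no measured step covers this change, so only a cautious expectation is possible: no shift beyond the usual scatter in this assay and no particular direction. That expectation rests on compound 1 with its limit of > 100000 nM as the nearest reference. Taken as a number, a number no higher from compound 1 to compound 3 (the limit leaves the size open) is expected to stay small. The estimated value for compound 3 is 100000 nM within an expected range of 40000 nM to 250000 nM and a further limit is the likeliest report.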

Compound 3, half-maximal inhibitory concentration: > 100000 nM
Compound 3: a limit, no number (the forecaster's own chance of this, stated with the estimate: 85%); the middle value sits exactly at the limit.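

In this assay compound 3 gives > 100000 nM, which is a limit and not a number. Compound 1 also stands at a limit, so no step can be read from compound 1 to compound 3 for hydrogen in place of chloro on an aromatic carbon. The compounds shown leave open how any change in structure would shift an exact value, since the record so far is a single ceiling: the limit of > 100000 nM in this assay, at which 3 of the 3 values shown sit.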